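A few compounds are considered here, and "the series" means these few. Any claim that something is new, unique, unknown or untested is made for them only; others in the source may bear on it.

Three compounds of a shared core have been examined in a functional assay on Hep 3B2 cells (Homo sapiens) for antiproliferative activity, read by MTT assay, with a stated time of 24 h, tested at 3.7 ug/mL; on this read-out higher numbers stand for a stronger effect at the one concentration tested and lower numbers for a weaker effect. Compound 1 `Cc1c(C(=O)Nc2c(F)cc(-c3cccc(F)c3)cc2F)nc2ccc(C(F)(F)F)cc2c1O` gives 31.2% in this assay. Compound 2 `COc1ccc2nc(C(=O)Nc3ccc(-c4ccccc4)cc3)c(C)c(O)c2c1` gives 23.5%, and compound 3 `Cc1c(C(=O)Nc2c(F)cc(-c3cccc(F)c3)cc2F)nc2ccc(C(F)(F)F)cc2c1C(=O)O` gives 21.3%. The values of compound 2 and compound 3 lie within the scatter of each other, as do those of compound 2 and compound 1. How the core of compound 2 differs from the core of compound 1 is not broken down here.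

Compound 3 carries one change against compound 1: carboxy in place of hydroxy on an aromatic carbon. That change made a step of a number 9.9 percentage points lower from compound 1 to compound 3 (within the scatter) in this assay. The same change, at the same place, leads from compound 2 to the as yet unmeasured compound 4 `COc1ccc2nc(C(=O)Nc3ccc(-c4ccccc4)cc3)c(C)c(C(=O)O)c2c1`: carboxy in place of hydroxy on an aromatic carbon.

Going by the values given here, for compound 4 the step in this assay is expected to be a number 8.5 percentage points lower from compound 2 to compound 4 (within the scatter), close to the earlier one, because the only measured example of this change gave a number 9.9 percentage points lower from compound 1 to compound 3 (within the scatter). The expectation rests on a single pair, so it is held loosely. The estimate for compound 4 in this assay is 15%, with a likely range from 3% to 27%.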

Compound 4, a percentage reported as inhibition, at one concentration (the size of the read-out at that concentration, not a potency): 19.4%
The estimate for compound 4 lay 4.4 percentage points below the measured number; the range from low to high includes it.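

In this assay, carboxy in place of hydroxy on an aromatic carbon gave a number 4.1 percentage points lower from compound 2 to compound 4 (within the scatter). Set beside the earlier step, the change reads much the same on the two cores: the same change on two cores in this assay, a number 9.9 percentage points lower (within the scatter) from compound 1 to compound 3 and a number 4.1 percentage points lower (within the scatter) from compound 2 to compound 4, 5.8 percentage points apart, within the scatter of two such steps. The two pairs therefore give no sign that the core alters the outcome of this change, but with both steps within the scatter they do not show that the change has a real effect on either core, and two pairs cannot establish a rule for the wider series.

The compounds shown leave open how an amine or a nitrile would read in this assay at this same place, opposite the ring nitrogen. They also leave open whether the step would stay the same on a core carrying a longer chain in place of the methyl group.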